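The source may hold more compounds than are shown below. What is called first, only, known or untested is meant among the compounds shown, and "the series" means these compounds.

Measured compounds:
compound 1, `Cc1cn2c(-c3cn[nH]c3)cnc2c(Nc2cc(Cc3cnccn3)ns2)n1`: 58.4 ng.h/mL
compound 2, `Cc1ccc(Cc2cc(Nc3nc(C)cn4c(-c5cn[nH]c5)cnc34)sn2)nc1`: 1370 ng.h/mL

Among the compounds with values here, in an ADME assay on the whole organism for pharmacokinetics, with Rattus norvegicus as the target, with a stated time of 6 h, at a dose of 10 mg/kg by the oral route (a lower number here means less compound in the circulation, a higher number more compound in the circulation at the dose given), compound 2 stands highest of the two measured compounds; the only other number lies well below it, as the step of a 23-fold higher number from compound 1 to compound 2 (1.37 log units; beyond the scatter) shows. Compound 3, `COc1cccc(Cc2cc(Nc3nc(C)cn4c(-c5cn[nH]c5)cnc34)sn2)n1`, has not yet been measured in this assay. It differs from compound 2 in one place: 6-methoxypyridin-2-yl in place of 5-methylpyridin-2-yl on a saturated chain carbon bound to an aromatic carbon. Within the data shown here, only one measured step touches the same place, the large one from compound 1 to compound 2, and it shows that swapping the group on that carbon can move the read-out far. The present swap is a different one, so a smaller step is expected, most likely a moderate drop, a 2.7-fold lower number from compound 2 to compound 3 (0.44 log units; beyond the scatter). Compound 3 is therefore estimated at 500 ng.h/mL, with a range from 120 ng.h/mL to 2000 ng.h/mL.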

Compound 3, area under the concentration-time curve: 2300 ng.h/mL
Estimate against measurement, compound 3: 4.6-fold (0.66 log units) below; measured number outside the range, above it.
By their numbers in this assay, from the lowest: compound 1; then compounds 2 and 3 (each within the scatter of the next).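

On the saturated chain carbon bound to an aromatic carbon, swapping 5-methylpyridin-2-yl for 6-methoxypyridin-2-yl gives a 1.7-fold higher number from compound 2 to compound 3 (0.23 log units; within the scatter) in this assay, so the two groups cannot be told apart here. Compound 2 alone could not show whether its high number was special to 5-methylpyridin-2-yl, but a second substituted pyridine group, this one carrying oxygen, now stands at the same level. Replacing pyrazin-2-yl with this group gives a 39-fold higher number from compound 1 to compound 3 (1.60 log units; beyond the scatter) and so a large step, as does the swap behind a 23-fold higher number from compound 1 to compound 2 (1.37 log units; beyond the scatter) in these three compounds.

From the compounds shown here alone, it remains open whether a pyridin-2-yl group carrying an amine or a carboxylic acid in place of the methoxy would stay at this level. Nothing given here explains any of these numbers.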